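From Compound 3 to Compound 4: A Smaller Side Group

This account rests on a few compounds, and the source may have more. Where it says the series, first, only, none or still open, it means among the compounds named here.

Among the measured compounds shown here, in a functional assay on A549 cells (Homo sapiens) for antiproliferative activity, read by sulforhodamine B assay, with a stated time of 3 days (on this read-out higher numbers stand for weaker inhibition of growth and lower numbers for stronger inhibition of growth), compound 3 `O=C(Nc1cc(Cl)cc(Cl)c1)c1cccc(Nc2ncc(F)c(Nc3ccc(F)cc3)n2)c1` gives 17500 nM, the higher of the two exact numbers so far. Compound 2 `O=C(Nc1cccc(Nc2ncc(F)c(Nc3ccc(F)cc3)n2)c1)c1cccc([N+](=O)[O-])c1` gives 7250 nM, lower by more than the usual scatter. Compound 1 `O=C(Nc1nccs1)c1cccc(Nc2ncc(F)c(Nc3ccc(F)cc3)n2)c1` gives > 10000 nM, which is a limit and not an exact number. For the measured compounds named here, the only measured step, a step that the limit leaves unreadable from compound 1 to compound 3, therefore offers no size to build on. Compound 4 `COCC(=O)Nc1cccc(Nc2ncc(F)c(Nc3ccc(F)cc3)n2)c1` carries ((methoxymethyl)carbonyl)amino in place of (3,5-dichlorophenyl)carbamoyl on an aromatic carbon. With no readable step to guide it, the expectation is no shift beyond the scatter, and the estimated step is a 1.6-fold lower number from compound 3 to compound 4 (0.20 log units; within the scatter). For compound 4 the estimated value is 11000 nM, with an expected range of 3500 nM to 30000 nM.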

Compound 4, concentration for 50% growth inhibition: 2050 nM
Beside the measured number, compound 4's estimate is 5.4-fold (0.73 log units) above it; measured number below the stated range.
By their numbers in this assay, from the lowest: compound 4; then compound 2; then compound 3.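

In this assay, the ((methoxymethyl)carbonyl)amino group, which has no ring, in place of the larger (3,5-dichlorophenyl)carbamoyl gives an 8.5-fold lower number from compound 3 to compound 4 (0.93 log units; beyond the scatter), the first readable size for a change at this position. Methoxymethyl in place of 3-nitrophenyl on the carbonyl carbon gives a 3.5-fold lower number from compound 2 to compound 4 (0.55 log units; beyond the scatter), so a ring is not needed on this side group for growth inhibition here. The third step, an at least 4.8-fold lower number from compound 1 to compound 4 (0.68 log units; beyond the scatter), starts from a limit and not from an exact number: the limit of > 10000 nM in this assay, at which 1 of the 4 values shown sits. From the compounds shown here alone, whether the gain comes from losing the ring or from methoxymethyl itself stays open. A longer carbon chain or an amine on that carbonyl carbon would help separate the two.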